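Methoxy to hydrogen on two related cores

The source may hold more compounds than are shown below. What is called first, only, known or untested is meant among the compounds shown, and "the series" means these compounds.

Measured compounds in a functional assay on HeLa cells (Homo sapiens) for inhibition, read by cell counting, with a stated time of 4 days; a lower number here means a stronger inhibitor, a higher number a weaker inhibitor:
compound 1 `Nc1cccc(-c2cn3nc(Cc4ccccc4)sc3n2)c1`, 24000 nM
compound 2 `COc1cccc(-c2nn3cc(-c4cccc(N)c4)nc3s2)c1`, 230000 nM
compound 3 `COc1cccc(Cc2nn3cc(-c4cccc(N)c4)nc3s2)c1`, 24000 nM

Compound 3 and compound 1 share a core and differ by hydrogen in place of methoxy on an aromatic carbon. That change gave no change at the digits printed from compound 3 to compound 1 (within the scatter). Compound 2 sits on a different core; how the two cores differ is not broken down here. In this assay compound 2 gives 230000 nM, the highest number of the three, clearly separated from compound 1 and compound 3.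

Compound 4 `Nc1cccc(-c2cn3nc(-c4ccccc4)sc3n2)c1` is not yet measured. Going by the values given here, it differs from compound 2 by hydrogen in place of methoxy on an aromatic carbon, the same change, at the same described place, as the one from compound 3 to compound 1. Among the compounds with values here, only that single earlier step is available as a guide, and it shows no movement within the scatter. Compound 4 is therefore expected to move by no change at the digits printed from compound 2 to compound 4 (within the scatter), resting on the earlier step of no change at the digits printed from compound 3 to compound 1 (within the scatter). For compound 4 the estimate in this assay is 230000 nM, expected to lie between 100000 nM and 500000 nM.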

Compound 4, half-maximal inhibitory concentration: 26000 nM
Estimate against measurement, compound 4: 8.8-fold (0.95 log units) above; the measured number lies below the stated range.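

In this assay, hydrogen in place of methoxy on an aromatic carbon does not carry over as a fixed shift from one core to the other: the same change on two cores in this assay, no change at the digits printed (within the scatter) from compound 3 to compound 1 and an 8.8-fold lower number (0.95 log units; beyond the scatter) from compound 2 to compound 4, 8.8-fold (0.95 log units) apart, beyond the scatter of two such steps. On the core of compound 2 the change gave an 8.8-fold lower number from compound 2 to compound 4 (0.95 log units; beyond the scatter), while phenyl in place of benzyl on an aromatic carbon, with no methoxy present, gave a 1.1-fold higher number from compound 1 to compound 4 (0.03 log units; within the scatter). With one pair on each core, this shows that the size of the step differed between these two cores, but it does not show why, nor what the step would be on any further core.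

The compounds shown leave open whether the high number of compound 2, 230000 nM, is particular to methoxy or would recur with other groups at that place. A hydroxyl, a fluorine or a longer chain such as ethoxy on each core would test this.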